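Closing the Amide Chain into a Ring

A few compounds are considered here, and "the series" means these few. Any claim that something is new, unique, unknown or untested is made for them only; others in the source may bear on it.

Measured so far:
compound 1, `COc1cc2c(cc1OC)C(CC(=O)NC(C)C)CC2` — 30%
compound 2, `CCCCNC(=O)CC1CCc2cc(OC)c(OC)cc21` — 36.7%
compound 3, `CCCCCNC(=O)CC1CCc2cc(OC)c(OC)cc21` — 46.7%
Not yet measured: compound 4, `COc1cc2c(cc1OC)C(CC(=O)N1CCCCC1)CC2`

In a functional assay on the whole organism (strain Wistar) for inhibition, with Rattus norvegicus as the target, read by paw edema, with stated times of 60 min and 24 h, at a dose of 100 mg/kg by the oral route (a higher number here means more inhibition at the dose given (going by the name of the read-out), a lower number less inhibition), compound 2 stands second highest of the three numbers. The steps of a number 6.7 percentage points higher from compound 1 to compound 2 (within the scatter) and a number 10 percentage points higher from compound 2 to compound 3 (within the scatter) are both within the usual scatter, so the three cannot be ordered with confidence. Among the compounds with values here, only the step of a number 16.7 percentage points higher from compound 1 to compound 3 (beyond the scatter) reaches beyond the scatter, and it is modest.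

Compound 4 changes compound 2 at the amide: piperidin-1-yl in place of butylamino on a carbonyl carbon. Within the data shown here, every measured step so far only lengthened or shortened the open chain on the amide-type nitrogen and left the hydrogen-bond donor in place. Among the measured compounds shown here, no measured pair closes the chain into a ring or removes that donor, so the measured steps give no direct guide for this change; they show only that changes at this position have moved the number little.

For compound 4 the step of a number 0.3 percentage points higher from compound 2 to compound 4 (within the scatter) is expected, with no movement beyond the scatter. Compound 4 is therefore estimated at 37%, in the range 20% to 55%.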

Compound 4, a percentage reported as inhibition, in the whole organism at one dose (the size of the read-out at that dose, not a potency): 40%
For compound 4 the middle estimate is 3 percentage points below the measured one; measured number inside the range.
By their numbers in this assay, from the lowest: compounds 1, 2, 4 and 3 (each within the scatter of the next, the first and the last beyond it).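

In this assay, replacing butylamino on the carbonyl carbon with piperidin-1-yl closes the open chain into a ring and removes its hydrogen-bond donor, and the result is a number 3.3 percentage points higher from compound 2 to compound 4 (within the scatter). Comparison with the other two open chains gives the same reading, with a number 6.7 percentage points lower from compound 3 to compound 4 (within the scatter) and a number 10 percentage points higher from compound 1 to compound 4 (within the scatter), so at this one dose neither the ring nor the loss of the amide hydrogen moves the number beyond the scatter. Nothing available here explains why the ring and the open chains give such similar numbers.

The compounds shown leave open whether a smaller ring, such as pyrrolidine, would also stay within the scatter of these compounds. They also leave open whether a ring carrying a second hetero atom, such as morpholine, would do so.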